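Chain extension on a weakly active indole amide core

This account rests on a few compounds, and the source may have more. Where it says the series, first, only, none or still open, it means among the compounds named here.

Measured compounds:
Compound 1 `CCCCNS(=O)(=O)c1ccc(Nc2ncc3c(n2)N(C2CCCC2)[C@H](CC)C(=O)N3C)cc1` gives 459 nM.
Compound 2 `CCCNS(=O)(=O)c1ccc(Nc2ncc3c(n2)N(C2CCCC2)[C@H](CC)C(=O)N3C)cc1` gives 344 nM.
Compound 3 `CCCNC(=O)c1ccc2c(ccn2-c2ncc3c(n2)N(c2ccn(C)n2)C(CC)C(=O)N3C)c1` gives 6420 nM.

The three measured compounds were tested in a functional assay on MCF7 cells (Homo sapiens) for antiproliferative activity, read by CCK-8 assay, with a stated time of 72 h; a higher number here means a weaker inhibitor of growth, a lower number a stronger inhibitor of growth. Compound 1 and compound 2 share one core; compound 3 is built on a different core, and the difference between the two cores is not broken down here. Compound 3 stands apart in this assay, with a value well beyond the scatter from either of the other two.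

Within the first pair, the change is methyl in place of hydrogen on a saturated chain carbon, three bonds along the chain from a sulfonamide nitrogen, and its effect is a 1.3-fold higher number from compound 2 to compound 1 (0.13 log units; within the scatter).

Compound 4 `CCCCNC(=O)c1ccc2c(ccn2-c2ncc3c(n2)N(c2ccn(C)n2)C(CC)C(=O)N3C)c1` is not yet measured. It differs from compound 3 by methyl in place of hydrogen on a saturated chain carbon, three bonds along the chain from an amide-type nitrogen. Going by the values given here, this is the same kind of change as the one from compound 2 to compound 1: in both cases a methyl enters in place of hydrogen on a saturated chain carbon, three bonds along the chain from a nitrogen; around the place, the nitrogen is a sulfonamide nitrogen in the first pair and an amide-type nitrogen in the second.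

For compound 4 in this assay the step is expected to be a 1.2-fold higher number from compound 3 to compound 4 (0.07 log units; within the scatter), resting on the earlier pair where the step was within the scatter, so the chain extension is expected to leave the value of compound 3 essentially where it is. Compound 4 is estimated at 7500 nM, with a range from 3500 nM to 16000 nM.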

Compound 4, concentration for 50% growth inhibition: 8990 nM
Compound 4: the middle estimate sits 1.2-fold (0.08 log units) below what was measured; the range from low to high includes it.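

In this assay, methyl in place of hydrogen on a saturated chain carbon, three bonds along the chain from an amide-type nitrogen, gives a 1.4-fold higher number from compound 3 to compound 4 (0.15 log units; within the scatter), a step that stays within the scatter. Set beside the earlier step, the same change reads alike on the two cores: the same change on two cores in this assay, a 1.3-fold higher number (0.13 log units; within the scatter) from compound 2 to compound 1 and a 1.4-fold higher number (0.15 log units; within the scatter) from compound 3 to compound 4, 1.0-fold (0.02 log units) apart, within the scatter of two such steps. This shows that, in these two pairs, going from propyl to butyl leaves the value essentially unmoved on either core, whether the nitrogen is a sulfonamide nitrogen or an amide-type nitrogen, but it does not show that the change has any real effect of its own, and two pairs in a single assay cannot establish that the same would hold on a third core.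

The compounds shown leave open whether a longer chain such as pentyl, a branched chain such as isobutyl, or a chain carrying an amine or a carboxylic acid in place of the butyl chain would move the value on either core. They also leave open which of the many differences between the two cores separates compound 3 and compound 4 from compound 1 and compound 2.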